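Series notes: heteroaryl swap on the chain carbon

The source may hold more compounds than are shown below. What is called first, only, known or untested is meant among the compounds shown, and "the series" means these compounds.

Measured so far:
compound 1, `CCn1ncc2c(C)cc(-c3ccc([C@@]4(C)CCNC4=O)c(=O)[nH]3)cc21`: 5 nM in an assay on CHO cells for displacement of a labelled ligand from prostaglandin E2 receptor EP3 subtype (Homo sapiens), read by radioligand binding; on this read-out higher numbers stand for weaker inhibition and lower numbers for stronger inhibition
compound 2, `CC(C)C(c1ccc(-c2ccc3cccc(F)c3c2)[nH]c1=O)N1CCN/C1=N\C#N`: 23 nM
compound 3, `CC(C)C(Nc1nccs1)c1ccc(-c2ccc3cccc(F)c3c2)[nH]c1=O`: 9.4 nM

Compound 3 stands second highest of the three numbers; its gap to compound 1 lies within the scatter, while its gap to compound 2 lies beyond it, as a 2.4-fold lower number from compound 2 to compound 3 (0.39 log units; beyond the scatter) shows.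

Compound 4, `Cc1c[nH]c(C(c2ccc(-c3ccc4cccc(F)c4c3)[nH]c2=O)C(C)C)n1`, differs from compound 3 by 4-methyl-1H-imidazol-2-yl in place of (1,3-thiazol-2-yl)amino on a saturated chain carbon bound to an aromatic carbon and a saturated chain carbon. Going by the values given here, only one measured step touches this chain carbon, a 2.4-fold lower number from compound 2 to compound 3 (0.39 log units; beyond the scatter), and that step was modest. A step of similar, modest size in this assay is therefore expected for compound 4, with the direction uncertain and a slight lean toward a higher number. For compound 4 the expected step is a 1.6-fold higher number from compound 3 to compound 4 (0.20 log units; within the scatter). The estimate for compound 4 is 15 nM, within a range of 4 nM to 60 nM.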

Compound 4, inhibition constant: 12 nM
Compound 4: the middle estimate sits 1.3-fold (0.10 log units) above what was measured; low and high end bracket the measured number.
By their numbers in this assay, from the lowest: compounds 1, 3, 4 and 2 (each within the scatter of the next, the first and the last beyond it).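

In this assay, 4-methyl-1H-imidazol-2-yl in place of (1,3-thiazol-2-yl)amino gives a 1.3-fold higher number from compound 3 to compound 4 (0.11 log units; within the scatter), so on this chain carbon the drop in hydrogen-bond acceptors from 3 to 1 and the swap of sulfur for carbon leave the number within the scatter. The group of 8 heavy atoms also stays close to the imidazole, with a 1.9-fold lower number from compound 2 to compound 4 (0.28 log units; within the scatter). No measurement bears on the cause of these steps.

The compounds shown leave open how a plain amine or a carboxylic acid would read on this chain carbon. They also leave open whether the tolerance seen here extends to a six-membered aromatic ring such as pyridine.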